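The source may hold more compounds than are shown below. What is called first, only, known or untested is meant among the compounds shown, and "the series" means these compounds.

Measured so far in this set:
compound 1 `Cc1ncc(-c2ccccc2NCC2=NCCN2)o1` — < 5020 nM (a limit)
compound 2 `Cc1nc(-c2ccccc2NCC2=NCCN2)cs1` — < 5020 nM (a limit)
compound 3 `c1ccc(-c2cnccn2)c(NCC2=NCCN2)c1` — 182 nM

In a functional assay for activation of Alpha-1D adrenergic receptor (Homo sapiens) (a lower number here means that less compound is needed, a higher number that more compound is needed for the effect), compound 1 gives < 5020 nM, which is a limit of the assay and not a number. In this assay compound 2 likewise gives < 5020 nM, again a limit. Among the compounds with values here, compound 3 is the only compound with an actual number, 182 nM, so it stands alone on the scale; the other two entries sit at the limit of < 5020 nM in this assay, at which 2 of the 3 values shown sit. The steps a step that the two limits leave unreadable from compound 1 to compound 2, a step that the limit leaves unreadable from compound 1 to compound 3 and a step that the limit leaves unreadable from compound 2 to compound 3 are all unreadable for that reason, and no sizing of a change on the aromatic carbon can be taken from them.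

Compound 4 `CCO/N=C(\C)c1ccccc1NCC1=NCCN1` carries a group of 6 heavy atoms (4 carbon, 1 nitrogen, 1 oxygen; no ring) in place of a group of 6 heavy atoms (4 carbon, 2 nitrogen; one six-membered aromatic ring with 2 hetero atoms), on an aromatic carbon. Within the data shown here, none of the measured steps bears directly on this exchange: all three swap one ring for another ring, whereas here the ring is replaced by an open chain carrying a double bond outside aromatic rings. With only compound 3 as a numbered anchor, the expectation rests on that single value and on the shared core being kept intact. The step of a 2.7-fold higher number from compound 3 to compound 4 (0.44 log units; beyond the scatter) is estimated to be modest, with a wide band around it. Compound 4 is expected to give about 500 nM, within 100 nM to 3000 nM, pending the measurement.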

Compound 4, half-maximal effective concentration: < 5020 nM
Compound 4 ended at the assay's limit (the forecaster's own chance of this, stated with the estimate: 15%); the middle value is on the limit's open side.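

In this assay compound 4 gives < 5020 nM, a limit and not a number. Its steps to compound 1, compound 2 and compound 3 cannot be read, and compound 4 joins the compounds at the limit: the limit of < 5020 nM in this assay, at which 3 of the 4 values shown sit.

The compounds shown leave open how far compound 1, compound 2 and compound 4 actually lie from compound 3 in this assay.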